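Propyl in Place of Dimethylaminophenyl on the Exocyclic Alkene

The compounds below may be only part of what the source reports. "The series", "measured", "known", "first", "only" and "open" are said of these compounds alone.

Compound 2 `CC(=O)OC[C@H]1O[C@@H](n2cc(CN3C(=O)/C(=C/c4ccc(N(C)C)cc4)c4ccccc43)nn2)[C@H](OC(C)=O)[C@@H](OC(C)=O)[C@@H]1OC(C)=O` gives 11200 nM in a functional assay on DU-145 cells (Homo sapiens) for cytotoxicity, read by sulforhodamine B assay, with a stated time of 48 h (a lower number here means a stronger inhibitor, a higher number a weaker inhibitor), and stands together with compound 1 `CC(=O)OC[C@H]1O[C@@H](n2cc(CN3C(=O)/C(=C\c4ccc(N(C)C)cc4)c4ccccc43)nn2)[C@H](OC(C)=O)[C@@H](OC(C)=O)[C@@H]1OC(C)=O`, which in this assay gives 10100 nM. Among the measured compounds shown here, the only measured step, a 1.1-fold higher number from compound 1 to compound 2 (0.04 log units; within the scatter), rests on the fact that compounds 1 and 2 differ only in the configuration as drawn and lies within the scatter. Compound 3 `CCC/C=C1/C(=O)N(Cc2cn([C@@H]3O[C@H](COC(C)=O)[C@@H](OC(C)=O)[C@H](OC(C)=O)[C@H]3OC(C)=O)nn2)c2ccccc21` differs from compound 2 by propyl in place of 4-(dimethylamino)phenyl on a double-bonded chain carbon bound to a double-bonded ring carbon. For the measured compounds named here, no measured step bears on that change, so the data give no guide to its direction, and the step could be small or large. Compound 3 is estimated at 20000 nM, between 7000 nM and 60000 nM, which would mean an expected step of a 1.8-fold higher number from compound 2 to compound 3 (0.25 log units; within the scatter).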

Compound 3, half-maximal inhibitory concentration: 19700 nM
For compound 3 the middle estimate is 1.0-fold (0.01 log units) above the measured one, and the stated range covers the measured number.
By their numbers in this assay, from the lowest: compounds 1, 2 and 3 (each within the scatter of the next).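

Replacing 4-(dimethylamino)phenyl with propyl on the double-bonded chain carbon gives a 1.8-fold higher number from compound 2 to compound 3 (0.25 log units; within the scatter) in this assay. Compounds 1 and 2 showed only that the drawn configuration of the double bond leaves the numbers within the scatter, whereas compound 3 shows that this place also accepts a chain without an aromatic ring, with no change readable beyond the scatter. Nothing available explains this step. The compounds shown leave open whether a longer chain, a primary amine or a carboxylic acid at this place would read differently.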